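The source may report more compounds than this note shows. Statements on the series, on what has been measured and on what is new or still open speak of the compounds shown alone.

Measured compounds:
compound 1, `CCCCCCCCC(=O)N1c2ccccc2CCC1C(=O)Nc1ccccc1C(F)(F)F`, in a functional assay on PC-3 cells (Homo sapiens) for cytotoxicity, read by sulforhodamine B assay, with a stated time of 72 h (a lower number here means a stronger inhibitor of growth, a higher number a weaker inhibitor of growth), gives 4320 nM
compound 2, `CCC(=O)N1c2ccccc2CCC1C(=O)Nc1ccccc1C(F)(F)F`, in this assay is reported only as a limit, > 80000 nM
compound 3, `O=C(Nc1ccccc1O)C1CCc2ccccc2N1`, in this assay gives 4310 nM

Compound 2 stands at the weak end of these numbers, sitting at the limit of > 80000 nM in this assay, at which 1 of the 3 values shown sits. Compound 1 and compound 3 both give numbers well below that limit, so both inhibit growth more strongly than compound 2.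

The new compound is compound 4, `O=C(Nc1ccccc1C(F)(F)F)C1CCc2ccccc2N1C(=O)c1ccccc1Cl`. The change from compound 2 is 2-chlorophenyl in place of ethyl on a carbonyl carbon. Within the data shown here, one measured step bears on this: an at least 18-fold higher number from compound 1 to compound 2 (1.26 log units; beyond the scatter). That step shows that stripping a long chain from the same acyl position makes the number jump past the limit, so putting a larger group back on that carbonyl carbon is expected to move the number down again, toward where compound 1 sits. Going by these compounds, whether an aromatic ring acts like a long chain here is untested, so the expectation is kept wide. The expected step is an at least 8.0-fold lower number from compound 2 to compound 4 (0.90 log units; beyond the scatter). Compound 4 is therefore estimated at 10000 nM, in the range 2000 nM to 60000 nM.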

Compound 4, concentration for 50% growth inhibition: 5140 nM
Estimate against measurement, compound 4: 1.9-fold (0.29 log units) above; low and high end bracket the measured number.
By their numbers in this assay, from the lowest: compounds 3, 1 and 4 (each within the scatter of the next). At a limit, above all of these: compound 2.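

In this assay, compound 2 is reported only as a limit, > 80000 nM. Among these compounds, putting 2-chlorophenyl in place of ethyl on the carbonyl carbon gives an at least 15-fold lower number from compound 2 to compound 4 (1.19 log units; beyond the scatter), so a long chain is not the only group at this position that goes with a measurable growth inhibition. Putting 2-chlorophenyl in place of octyl at the same carbon gives a 1.2-fold higher number from compound 1 to compound 4 (0.08 log units; within the scatter), so the ring and the long chain cannot be told apart here.

Still open, going by these compounds, is how a plain phenyl or a butyl chain on that carbonyl carbon would compare, which would show whether the chlorine matters and how much chain is needed. Compound 3 differs from the others in more than one place, so it cannot show whether this trend holds on a core with a free ring nitrogen.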